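The compounds below may be only part of what the source reports. "The series", "measured", "known", "first", "only" and "open" are said of these compounds alone.

In a functional assay on A549 cells (Homo sapiens) for cytotoxicity, read by MTT assay, with a stated time of 72 h (a higher number here means a weaker inhibitor, a lower number a stronger inhibitor), three compounds with a shared core have been measured: compound 1 `Cc1ccc(Cn2cc(/C=N/NC(=O)Nc3nc4ccc(CN(C)C)cc4s3)c3ccccc32)cc1` gives 1600 nM, compound 2 `CN(C)Cc1ccc2nc(NC(=O)N/N=C/c3cn(Cc4cccc(Cl)c4)c4ccccc34)sc2c1` gives 1240 nM and compound 3 `CN(C)Cc1ccc2nc(NC(=O)N/N=C/c3cn(Cc4ccc(Cl)cc4Cl)c4ccccc34)sc2c1` gives 2000 nM. They differ only in the phenyl group on a saturated chain carbon bound to an aromatic nitrogen, and compound 3 stands within the usual scatter of the other two. Compound 4 `CN(C)Cc1ccc2nc(NC(=O)N/N=C/c3cn(Cc4ccc(Cl)c(Cl)c4)c4ccccc34)sc2c1` carries 3,4-dichlorophenyl in place of 2,4-dichlorophenyl on a saturated chain carbon bound to an aromatic nitrogen. Going by the values given here, the steps that bear on this change are those made at the same place: a 1.3-fold lower number from compound 1 to compound 2 (0.11 log units; within the scatter), a 1.3-fold higher number from compound 1 to compound 3 (0.10 log units; within the scatter) and a 1.6-fold higher number from compound 2 to compound 3 (0.21 log units; within the scatter). All three lie within the scatter, although none of them compares two dichlorophenyl groups directly. No step beyond the scatter is therefore expected in this assay, and no firm direction either. The expected step is a 1.3-fold lower number from compound 3 to compound 4 (0.10 log units; within the scatter). Compound 4 is estimated at 1600 nM, with an expected range from 800 nM to 3200 nM.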

Compound 4, half-maximal inhibitory concentration: 940 nM
The estimate for compound 4 lay 1.7-fold (0.23 log units) above the measured number; measured number inside the range.
By their numbers in this assay, from the lowest: compounds 4, 2, 1 and 3 (each within the scatter of the next, the first and the last beyond it).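

In this assay, going by these compounds alone, the same atoms rearranged on the benzyl group, 2,4-dichlorobenzyl to 3,4-dichlorobenzyl, give a 2.1-fold lower number from compound 3 to compound 4 (0.33 log units; beyond the scatter), the first modest step beyond the scatter at this position. The other new steps, a 1.3-fold lower number from compound 2 to compound 4 (0.12 log units; within the scatter) and a 1.7-fold lower number from compound 1 to compound 4 (0.23 log units; within the scatter), stay within the scatter, so only the comparison of the two dichlorophenyl groups separates compounds here, and 3,4-dichlorophenyl does not stand apart from 3-chlorophenyl or 4-methylphenyl. Nothing available explains why these two dichlorophenyl groups differ.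

Going by these compounds, all four compounds carry a phenyl group with only chloro or methyl on it, so the effect of an amine or a carboxylic acid on that ring remains open. A longer chain between the aromatic nitrogen and the phenyl ring is also untested among the compounds shown.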